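Swapping Hydroxy for Trifluoromethyl on a Sulfonamide Series

This account rests on a few compounds, and the source may have more. Where it says the series, first, only, none or still open, it means among the compounds named here.

Measured compounds:
- Compound 1, `O=S(=O)(Nc1ccc(-c2nc3ccccc3o2)cc1)c1cccc(F)c1`: in an assay on isolated protein for inhibition of malate dehydrogenase, mitochondrial (Sus scrofa), with stated times of 45 min and 30 min (on this read-out higher numbers stand for weaker inhibition and lower numbers for stronger inhibition), compound 1 gives only a limit, > 63000 nM.
- Compound 2, `O=S(=O)(Nc1ccc(-c2nc3ccccc3o2)cc1)c1cccc(O)c1`: in this assay compound 2 gives only a limit, > 63000 nM.
- Compound 3, `CS(=O)(=O)Nc1ccc(-c2nc3ccccc3o2)cc1`: in this assay compound 3 gives only a limit, > 63000 nM.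

Compound 2 therefore stands on a limit of this assay rather than a number, and the two other measured values are limits as well, all at the limit of > 63000 nM in this assay, at which 3 of the 3 values shown sit. The unmeasured compound 4, `O=S(=O)(Nc1ccc(-c2nc3ccccc3o2)cc1)c1cccc(C(F)(F)F)c1`, differs from compound 2 by trifluoromethyl in place of hydroxy on an aromatic carbon. The measured steps that bear on this change are a step that the two limits leave unreadable from compound 1 to compound 2, a step that the two limits leave unreadable from compound 2 to compound 3 and a step that the two limits leave unreadable from compound 1 to compound 3; none of them can be read in size, because all their end points sit on (the limit of > 63000 nM in this assay, at which 3 of the 3 values shown sit). Among the compounds with values here, no measured step shows that a group on this ring, or the whole sulfonyl substituent, moves the read-out past the limit. The step from compound 2 to compound 4 in this assay is thus expected to be unreadable too, and the likely outcome is another limit: a step that the limit leaves unreadable from compound 2 to compound 4. Compound 4 is estimated at 100000 nM, within 30000 nM to 400000 nM.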

Compound 4, half-maximal inhibitory concentration: > 63000 nM
Compound 4 gave a limit, no number; the forecaster's own chance of this, stated with the estimate: 85%; the middle value lies beyond the limit too.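

Compound 4 gives only a limit, so neither the step to it from compound 2 nor the step to it from compound 1 can be read in size: the limit of > 63000 nM in this assay, at which 4 of the 4 values shown sit. The compounds shown leave open whether any sulfonyl substituent gives a real number in this assay and how large these steps truly are.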